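The compounds below may be only part of what the source reports. "The series", "measured", "known", "first", "only" and "open" are said of these compounds alone.

Measured compounds:
Compound 1 `Cc1nnc(SCC(=O)c2ccc(Cl)cc2)n1N1C(=O)c2ccccc2C1=O`: in a functional assay on HepG2 cells (Homo sapiens) for cytotoxicity, read by MTT assay, with a stated time of 48 h (on this read-out lower numbers stand for stronger inhibition and higher numbers for weaker inhibition), compound 1 gives > 200000 nM, which is a limit of the assay and not a number.
Compound 2 `Cc1ccc(C(=O)CSc2nnc(C)n2N2C(=O)c3ccccc3C2=O)cc1`: in this assay compound 2 gives > 200000 nM, again a limit.
Compound 3 `CCCc1nnc(SCC(=O)c2ccc(Cl)cc2)n1N1C(=O)c2ccccc2C1=O`: in this assay compound 3 gives > 200000 nM, also a limit.

Within the data shown here, all three values sit at the limit of > 200000 nM in this assay, at which 3 of the 3 values shown sit, so no step between them can be read. From compound 1 to compound 2 the change is methyl in place of chloro on an aromatic carbon, and the result is a step that the two limits leave unreadable from compound 1 to compound 2. The two cores differ by ethyl in place of hydrogen on a saturated chain carbon bound to an aromatic carbon, and here too a step that the two limits leave unreadable from compound 1 to compound 3.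

Compound 4 `CCCc1nnc(SCC(=O)c2ccc(C)cc2)n1N1C(=O)c2ccccc2C1=O` has not been measured in this assay. It differs from compound 3 by methyl in place of chloro on an aromatic carbon, the same change as from compound 1 to compound 2, made on the other core and at the same place. The earlier instance of this change left two limits, so the size of the step it made is not readable. The expectation for compound 4 therefore rests only on where compound 3 stands. Compound 3 gives > 200000 nM, a limit. Among the measured compounds shown here, on that the expected step from the one to the other is a step that the limit leaves unreadable from compound 3 to compound 4, with no measured step to say otherwise. Compound 4 is estimated at 300000 nM, expected between 150000 nM and 1000000 nM, and most probably reported once more only as a limit.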

Compound 4, half-maximal inhibitory concentration: > 200000 nM
Compound 4 was reported as a limit; the forecaster's own chance of this, stated with the estimate: 85%; the middle value does not contradict the limit.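

No new step can be read from compound 3 to compound 4 or from compound 2 to compound 4 in this assay, because all four compounds share one limit of the assay: the limit of > 200000 nM in this assay, at which 4 of the 4 values shown sit.

The compounds shown leave open whether methyl in place of chloro, or ethyl in place of hydrogen, changes the cytotoxicity of this series at all, and by how much.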